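Removing the methylene between amide and fluorophenyl ring

A few compounds are considered here, and "the series" means these few. Any claim that something is new, unique, unknown or untested is made for them only; others in the source may bear on it.

Of the compounds shown here, three of a shared core have been measured in a functional assay on MCF7 cells (Homo sapiens) for inhibition, read by MTT assay; a lower number here means a stronger inhibitor of growth, a higher number a weaker inhibitor of growth. Compound 1 `CC1=C(/C=C/C(C)=C/C=C/C(C)=C\C(=O)NCc2ccc(F)cc2)C(C)(C)CCC1n1ccnc1` gives 1930 nM in this assay. Compound 2 `CC1=C(/C=C/C(C)=C/C=C/C(C)=C\C(=O)NCc2ccc(O)cc2)C(C)(C)CC=C1c1cncnc1` gives 4960 nM. Compound 3 `CC1=C(/C=C/C(C)=C/C=C/C(C)=C\C(=O)NCc2cccc(F)c2)C(C)(C)CCC1n1ccnc1` gives 1810 nM, the lowest of the three numbers, though its gap to compound 1 lies within the scatter, so no order between those two can be read; only compound 2 stands apart from it, beyond the scatter. Going by the values given here, the one step between compounds that differ in a single place, a 1.1-fold lower number from compound 1 to compound 3 (0.03 log units; within the scatter), lies within the scatter.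

Compound 4 `CC1=C(/C=C/C(C)=C/C=C/C(C)=C\C(=O)Nc2cccc(F)c2)C(C)(C)CCC1n1ccnc1` differs from compound 3 by 3-fluorophenyl in place of 3-fluorobenzyl on an amide-type nitrogen, so that (3-fluorobenzyl)carbamoyl becomes (3-fluorophenyl)carbamoyl. Among the compounds with values here, no measured step bears on this change: the only measured step concerns where the fluorine sits on the ring, not what joins the ring to the amide-type nitrogen. The expectation for compound 4 therefore rests on compound 3 alone, and a step of a 1.2-fold lower number from compound 3 to compound 4 (0.08 log units; within the scatter) is expected, with the direction left open and a wide range. Compound 4 is estimated to give 1500 nM in this assay, between 500 nM and 4500 nM.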

Compound 4, concentration for 50% growth inhibition: 5490 nM
For compound 4 the middle estimate is 3.7-fold (0.56 log units) below the measured one, outside the stated range (above it).
By their numbers in this assay, from the lowest: compounds 3 and 1 (each within the scatter of the next); then compounds 2 and 4 (each within the scatter of the next).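

In this assay the link joining the fluorinated ring to the amide-type nitrogen matters in a way the fluorine's place on the ring did not: the earlier change of ring substitution stayed within the scatter, whereas replacing 3-fluorobenzyl with 3-fluorophenyl gives a 3.0-fold higher number from compound 3 to compound 4 (0.48 log units; beyond the scatter). The comparison with the 4-fluorobenzyl compound points the same way, with a 2.8-fold higher number from compound 1 to compound 4 (0.45 log units; beyond the scatter), so both benzyl amides in this series have numbers lower than the directly attached phenyl amide, and each step is modest but beyond the scatter. No supporting data are available to explain why removing the methylene weakens growth inhibition in these cells.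

The compounds shown leave open whether a longer chain joining the ring to the amide-type nitrogen, such as 2-(3-fluorophenyl)ethyl, would keep the number close to that of the benzyl amides or shift it further. They also leave open whether the same loss appears when the ring carries a group other than fluorine, such as an amine or a carboxylic acid, or when the change is made on the core of compound 2.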